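A Methyl Added to Compound 2

The source may hold more compounds than are shown below. What is called first, only, known or untested is meant among the compounds shown, and "the series" means these compounds.

Measured compounds:
Compound 1, `NS(=O)(=O)c1ccc(N2N=C(c3ccc(F)cc3)CC2c2cn(-c3ccccc3)nc2-c2ccccc2)cc1`: 25%
Compound 2, `Cc1ccc(-c2nn(-c3ccccc3)cc2C2CC(c3ccccc3)=NN2c2ccc(S(N)(=O)=O)cc2)cc1`: 14%

Of the compounds shown here, two have been tested in a functional assay on the whole organism (strain Wistar albino) for inhibition, with Rattus norvegicus as the target, read by paw edema, with stated times of 30 min and 60 min, at a dose of 50 mg/kg by the oral route; a higher number here means more inhibition at the dose given (going by the name of the read-out), a lower number less inhibition. Compound 1 gives 25%. Compound 2 gives 14%, the lower of the two numbers, and the gap to compound 1 lies beyond the usual scatter of this kind of measurement. Within the data shown here, the two measured compounds differ from each other in more than one place, so no single structural change can be tied to that gap, and no step between measured compounds is known.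

Compound 3, `Cc1ccc(C2=NN(c3ccc(S(N)(=O)=O)cc3)C(c3cn(-c4ccccc4)nc3-c3ccc(C)cc3)C2)cc1`, is the next compound, and it differs from compound 2 in one place only: methyl in place of hydrogen on an aromatic carbon. Among the measured compounds shown here, nothing among the measured compounds shows what a change of this size does in this assay. The author therefore expects the step from compound 2 to compound 3 to be small, one that stays within the scatter, and the expected step is a number 2 percentage points higher from compound 2 to compound 3 (within the scatter). On that basis compound 3 is estimated to give 16% in this assay, with an expected range from 5% to 30%.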

Compound 3, a percentage reported as inhibition, in the whole organism at one dose (the size of the read-out at that dose, not a potency): 19%
The estimate for compound 3 lay 3 percentage points below the measured number; measured number inside the range.
By their numbers in this assay, from the lowest: compounds 2, 3 and 1 (each within the scatter of the next, the first and the last beyond it).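

Among these compounds, the step from phenyl to 4-methylphenyl is the first change in one place that can be read in this assay, and it gives a number 5 percentage points higher from compound 2 to compound 3 (within the scatter). On this aromatic carbon, para to a large group, a methyl in place of hydrogen therefore leaves the inhibition of paw edema at this dose indistinguishable from that seen with hydrogen, which the earlier pair, differing in more than one place, could not show. This holds for one pair and one small group only, and nothing available offers a reason for the result.

Going by these compounds, whether an amine, a carboxylic acid or a longer chain on this same carbon would move the number beyond the scatter stays open, as does whether the methyl would read the same way on another ring of the molecule. Compound 1 differs from compound 2 in more than one place, so what separates those two numbers also remains unresolved.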